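This account rests on a few compounds, and the source may have more. Where it says the series, first, only, none or still open, it means among the compounds named here.

Of the compounds shown here, three have so far been tested in a functional assay on the whole organism for antagonist activity, with Mus musculus as the target; on this read-out lower numbers stand for an effect already at smaller amounts and higher numbers for an effect only at larger amounts of compound. Compound 1 (`CC(C#CCN(C)C)N1CCCC1=O`) gives > 100 mg/kg, which is a limit of the assay and not a number. Compound 2 (`COC(=O)N(C)C(C)C#CCN1CCCC1`) gives > 100 mg/kg, again a limit. Compound 3 (`O=C1OCCN1CC#CCn1ccnc1`) gives > 100 mg/kg, also a limit. The series therefore offers only (the limit of > 100 mg/kg in this assay, at which 3 of the 3 values shown sit), and compound 3 cannot be placed more exactly than that.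

Compound 4 (`Cc1cncn1CC#CCN1CCOC1=O`) differs from compound 3 in one place, with methyl in place of hydrogen on an aromatic carbon. Among the measured compounds shown here, no measured step between compounds is available as a guide, so no shift beyond the usual scatter is expected in this assay, in either direction. This expectation rests on compound 3, whose reading of > 100 mg/kg is a limit. The estimated change is a number no higher from compound 3 to compound 4 (the limit leaves the size open). Another limit reading would be no surprise. For compound 4 the expected value is 100 mg/kg, with an estimated range of 30 mg/kg to 300 mg/kg.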

Compound 4, dose for half-maximal effect: > 100 mg/kg
Compound 4 ended at the assay's limit; the forecaster's own chance of this, stated with the estimate: 65%; the middle value lies on the limit itself.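

No step can be read from compound 3 to compound 4, as both readings in this assay are limits and not numbers. The compounds shown leave open what structure, if any, would give a readable dose, as every reading stands at the same place: the limit of > 100 mg/kg in this assay, at which 4 of the 4 values shown sit.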